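This account rests on a few compounds, and the source may have more. Where it says the series, first, only, none or still open, it means among the compounds named here.

Measured compounds: compound 1 `CCCCSc1n[nH]c(-n2[se]c3ccccc3c2=O)n1` gives 12500 nM in a functional assay on A549 cells (Homo sapiens) for antiproliferative activity, read by CCK-8 assay, with a stated time of 48 h; a lower number here means a stronger inhibitor, a higher number a weaker inhibitor; compound 2 `O=c1c2ccccc2[se]n1-c1nc(SCc2ccc(F)cc2)n[nH]1` gives 36400 nM; compound 3 `O=c1c2ccccc2[se]n1-c1nc(SCc2ccc(Cl)cc2)n[nH]1` gives 42100 nM.

Compound 3 has the highest of the three numbers, though its gap to compound 2, a 1.2-fold higher number from compound 2 to compound 3 (0.06 log units; within the scatter), lies within the scatter. Compound 4 `CC(C)Sc1n[nH]c(-n2[se]c3ccccc3c2=O)n1` differs from compound 3 by isopropyl in place of 4-chlorobenzyl on a sulfur. For the measured compounds named here, the steps that bear on this change run the other way: a 2.9-fold higher number from compound 1 to compound 2 (0.46 log units; beyond the scatter) and a 3.4-fold higher number from compound 1 to compound 3 (0.53 log units; beyond the scatter), both modest and beyond the scatter, where a 4-fluorophenyl or 4-chlorophenyl group took the place of propyl. Returning to a short alkyl group on the sulfur is therefore expected to lower the number by a modest step, a 3.5-fold lower number from compound 3 to compound 4 (0.55 log units; beyond the scatter). Compound 4 is expected to give about 12000 nM, within a range from 5000 nM to 30000 nM.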

Compound 4, half-maximal inhibitory concentration: 36600 nM
Beside the measured number, compound 4's estimate is 3.1-fold (0.48 log units) below it; the measured number lies above the stated range.
By their numbers in this assay, from the lowest: compound 1; then compounds 2, 4 and 3 (each within the scatter of the next).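

In this assay, isopropyl on the sulfur gives a number level with both benzyl compounds (a 1.2-fold lower number from compound 3 to compound 4 (0.06 log units; within the scatter); a 1.0-fold higher number from compound 2 to compound 4 (0.00 log units; within the scatter)), so among these compounds the presence of an aromatic ring in the group does not by itself set compound 1 apart. The change from butyl to isopropyl alone accounts for a modest step beyond the scatter (a 2.9-fold higher number from compound 1 to compound 4 (0.47 log units; beyond the scatter)). No measurement offered here explains this.

From the compounds shown here alone, whether chain length or branching matters remains open, and a straight propyl would help separate them. A longer chain such as hexyl, or a chain ending in an amine, also remains untested in the compounds shown.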